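A few compounds are considered here, and "the series" means these few. Any claim that something is new, unique, unknown or untested is made for them only; others in the source may bear on it.

The set contains three measured compounds and one that is not yet measured. Compound 1 `C#CCOc1ccc(C(C)(C)C)cc1C1(c2ccccc2)C(=O)Nc2ccccc21` and compound 2 `CC(C)(C)c1ccc(OCC(=O)O)c(C2(c3ccccc3)C(=O)Nc3ccccc32)c1` share the core of compound 3 `COc1ccc(C2(c3cc(C(C)(C)C)ccc3O)C(=O)Nc3ccccc32)cc1`, and the fourth member is compound 4 `CN(C)c1ccc(C2(c3cc(C(C)(C)C)ccc3O)C(=O)Nc3ccccc32)cc1`. In a functional assay on cells (Mus musculus) for antiproliferative activity, read by sulforhodamine B assay, with a stated time of 5 days (a higher number here means a weaker inhibitor, a lower number a stronger inhibitor), compound 1 reaches only a limit of > 20000 nM. Compound 2 likewise gives only a limit, > 20000 nM, in this assay. Within the data shown here, the single measured step, a step that the two limits leave unreadable from compound 1 to compound 2, cannot be read because both of its ends sit at the limit of > 20000 nM in this assay, at which 2 of the 3 values shown sit. Among the measured compounds shown here, compound 3 is the one compound with a number: in this assay compound 3 gives 15700 nM, so it stands as the sole numeric reference point among the measured values.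

Compound 4 differs from compound 3 by dimethylamino in place of methoxy on an aromatic carbon. For the measured compounds named here, none of the measured steps touches this part of the molecule; the only recorded step concerns a different site and is itself unreadable. What can be said of compound 4 therefore rests on compound 3 alone, and no direction of change can be drawn from the measured compounds. The expected step is a 1.3-fold lower number from compound 3 to compound 4 (0.12 log units; within the scatter), which stays within the usual scatter. The estimate for compound 4 in this assay is 12000 nM, with a range from 4000 nM to 40000 nM, and a real chance that the result is again reported only as a limit.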

Compound 4, half-maximal inhibitory concentration: 10900 nM
For compound 4 the middle estimate is 1.1-fold (0.04 log units) above the measured one; low and high end bracket the measured number.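

Among these compounds, compound 3 and compound 4 supply the one step in this set that can be read as a number: in this assay the pair gives a 1.4-fold lower number from compound 3 to compound 4 (0.16 log units; within the scatter) and so lies within the usual scatter. Among the compounds shown here, at this position, on an aromatic carbon para to a large group, the change from 4-methoxyphenyl to 4-(dimethylamino)phenyl therefore does not separate the two compounds, which is something the earlier measurements could not show, since the only earlier step touches a different site and cannot be read. Nothing measured here offers a reason for this result.

The compounds shown leave open whether a group of another kind at this same place, such as a carboxylic acid, a nitrile or a primary amine, would give a step beyond the scatter, or whether a longer chain on the nitrogen would do so. They also leave open whether the same change from methoxy to dimethylamino would read alike on a compound that carries an ether chain on the oxygen of the other aromatic ring in place of the free hydroxy group.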